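This account rests on a few compounds, and the source may have more. Where it says the series, first, only, none or still open, it means among the compounds named here.

Compound 1 (`CCOC(=O)c1ccc(-c2nn(Cc3ccccc3F)c3ccccc23)cc1`) and compound 2 (`CCOC(=O)c1ccc(-c2nn(Cc3cccnc3)c3ccccc23)cc1`) share one core and differ only in the group on a saturated chain carbon bound to an aromatic nitrogen. In a functional assay on cells (Platelet, Homo sapiens) for inhibition (a higher number here means a weaker inhibitor, a lower number a stronger inhibitor), compound 1 gives a limit and not a number (> 10000 nM). In this assay compound 2 also gives a limit and not a number (> 10000 nM). For the measured compounds named here, compound 2 therefore has no exact place, and both values so far sit at the same limit (the limit of > 10000 nM in this assay, at which 2 of the 2 values shown sit).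

Compound 3 (`CCOC(=O)c1ccc(-c2nn(CC)c3ccccc23)cc1`) has methyl in place of pyridin-3-yl at that same place (methyl in place of pyridin-3-yl on a saturated chain carbon bound to an aromatic nitrogen). Cut one bond further out, the change reads (pyridin-3-yl)methyl to ethyl. Going by the values given here, the only measured step at this place is a step that the two limits leave unreadable from compound 1 to compound 2 and it offers no size to carry over. Neither group tried there has yet given a number, so compound 3 is expected to stay near the limit in this assay, most likely reported as a limit again. The estimated step has no direction that the data can support (a step that the limit leaves unreadable from compound 2 to compound 3). Compound 3 is estimated at 15000 nM (expected range 5000 nM to 50000 nM).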

Compound 3, half-maximal inhibitory concentration: > 10000 nM
Compound 3 ended at the assay's limit; the forecaster's own chance of this, stated with the estimate: 85%; the middle value lies beyond the limit too.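

In this assay compound 3 gives > 10000 nM as a limit and not a number. For the compounds shown here, the steps among compound 1, compound 2 and compound 3 therefore cannot be read, and no new step emerges: the limit of > 10000 nM in this assay, at which 3 of the 3 values shown sit.

The compounds shown leave open how 2-fluorophenyl, pyridin-3-yl and methyl on a saturated chain carbon bound to an aromatic nitrogen actually compare.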